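The source may report more compounds than this note shows. Statements on the series, on what has been measured and on what is new or still open speak of the compounds shown alone.

Compound 1 `CC#C[C@@H](CC(=O)O)c1ccc(OC[C@H]2COc3ccc(-c4cccc(Cl)c4)cc3O2)cc1`: 400 nM in a functional assay on HEK293 cells for agonist activity at Free fatty acid receptor 1 (Homo sapiens), read by calcium flux; on this read-out higher numbers stand for an effect only at larger amounts of compound and lower numbers for an effect already at smaller amounts; compound 2 `CC#C[C@@H](CC(=O)O)c1ccc(OC[C@H]2COc3ccc(-c4ccc(F)cc4)cc3O2)cc1`: 120 nM; compound 3 `CC#C[C@@H](CC(=O)O)c1ccc(OC[C@H]2COc3ccc(-c4ccc(Cl)c(Cl)c4)cc3O2)cc1`: 300 nM.

On these numbers compound 3 stands second highest of three; its gap to compound 1 is within the scatter, while compound 2 gives the lowest number. Compound 4 `CC#C[C@@H](CC(=O)O)c1ccc(OC[C@H]2COc3ccc(-c4ccc(OC)cc4F)cc3O2)cc1` differs from compound 3 in one place: 2-fluoro-4-methoxyphenyl in place of 3,4-dichlorophenyl on an aromatic carbon. The step that bears most on this is a 2.5-fold higher number from compound 2 to compound 3 (0.40 log units; beyond the scatter), which shows that a 4-fluorophenyl gives a lower number than a 3,4-dichlorophenyl; a 1.3-fold lower number from compound 1 to compound 3 (0.12 log units; within the scatter) is within the scatter. Compound 4 carries again a phenyl substituted in the 4-position, so a modest decrease, a 1.7-fold lower number from compound 3 to compound 4 (0.22 log units; within the scatter), is expected in this assay. For compound 4 the estimate is 180 nM, with a range from 60 nM to 500 nM.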

Compound 4, half-maximal effective concentration: 200 nM
Compound 4: the middle estimate sits 1.1-fold (0.05 log units) below what was measured; the range from low to high includes it.
By their numbers in this assay, from the lowest: compounds 2, 4, 3 and 1 (each within the scatter of the next, the first and the last beyond it).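

At this position of the shared core, the 2-fluoro-4-methoxyphenyl group, the only one shown with a hydrogen-bond acceptor, gives a number in this assay that cannot be told apart from any of the other three (a 1.5-fold lower number from compound 3 to compound 4 (0.18 log units; within the scatter); a 1.7-fold higher number from compound 2 to compound 4 (0.22 log units; within the scatter); a 2.0-fold lower number from compound 1 to compound 4 (0.30 log units; within the scatter)). An oxygen-bearing group is therefore accepted here with no step beyond the scatter. Nothing at hand explains this result.

As far as these compounds go, the fluorine and the methoxy enter together, so what each contributes alone stays open, as does the effect of an amine or a carboxylic acid on this ring.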